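This account rests on a few compounds, and the source may have more. Where it says the series, first, only, none or still open, it means among the compounds named here.

Compound 1, `COc1cccc(NC2=CC(=O)c3c(nc4n3[C@H]3OC[C@@H](O)[C@H]3OC4)C2=O)c1`, in a functional assay on ECa-109 cells for inhibition, with ECa-109 cell line (Homo sapiens) as the target, read by sulforhodamine B assay (on this read-out higher numbers stand for weaker inhibition and lower numbers for stronger inhibition), gives 3340 nM.
Compound 2, `O=C1C(NC2CCCC2)=CC(=O)c2c1nc1n2[C@H]2OC[C@@H](O)[C@H]2OC1`, in this assay gives only a limit of the assay, > 16000 nM.
Compound 3, `CCOc1ccccc1NC1=CC(=O)c2c(nc3n2[C@H]2OC[C@@H](O)[C@H]2OC3)C1=O`, in this assay gives 4320 nM.

Among the two plain numbers, compound 3 has the highest, but the gap to compound 1, a 1.3-fold higher number from compound 1 to compound 3 (0.11 log units; within the scatter), lies within the usual scatter, so the two cannot be ranked. Compound 4, `O=C1C(NC2CCCCC2)=CC(=O)c2c1nc1n2[C@H]2OC[C@@H](O)[C@H]2OC1`, is not yet measured; it differs from compound 3 in one place: cyclohexyl in place of 2-ethoxyphenyl on an amine nitrogen.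

For the measured compounds named here, two measured steps bear on this change. Swapping an aromatic ring for a saturated one on the same amine nitrogen gave an at least 4.7-fold higher number from compound 1 to compound 2 (0.68 log units; beyond the scatter), and the reverse swap gave an at least 3.7-fold lower number from compound 2 to compound 3 (0.56 log units; beyond the scatter), where compound 2 sits at the limit (the limit of > 16000 nM in this assay, at which 1 of the 3 values shown sits). Both steps say that a saturated ring on that nitrogen weakens inhibition by at least a modest amount. Cyclohexyl is one carbon larger than cyclopentyl, and nothing measured here separates the two, so the same direction and size are expected for compound 4 in this assay: an estimated step of a 4.6-fold higher number from compound 3 to compound 4 (0.67 log units; beyond the scatter). Compound 4 is therefore expected to give about 20000 nM, with a likely range of 8000 nM to 60000 nM, and a real chance that only a limit of the assay is reported.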

Compound 4, half-maximal inhibitory concentration: > 16000 nM
Compound 4 was reported as a limit; the forecaster's own chance of this, stated with the estimate: 60%; the middle value is on the limit's open side.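

Cyclopentyl was the only saturated ring on this amine nitrogen before, so the loss of inhibition could have belonged to that one group. In this assay, cyclohexyl shows the same direction against both aromatic partners, with an at least 3.7-fold higher number from compound 3 to compound 4 (0.56 log units; beyond the scatter) and an at least 4.7-fold higher number from compound 1 to compound 4 (0.68 log units; beyond the scatter), so within these four compounds the loss is not tied to a single saturated ring size. Compound 2 and compound 4 each stand as a limit, so the step between them cannot be read and the two saturated rings cannot be ranked: the limit of > 16000 nM in this assay, at which 2 of the 4 values shown sit.

Each swap from an aromatic to a saturated ring also removes the ether oxygen carried by the aromatic groups, so these compounds cannot say whether the ring type, the oxygen or both go with the change; a plain phenyl group and a methoxycyclohexyl group would pull those two apart. Also open, as far as these compounds go, is what a benzyl group, a pyridyl ring or an open butyl chain on this nitrogen would give.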